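Paw edema series: chloro added to the aryl ring

The compounds below may be only part of what the source reports. "The series", "measured", "known", "first", "only" and "open" are said of these compounds alone.

Measured so far in a functional assay on the whole organism (strain Wister albino) for inhibition, with Rattus norvegicus as the target, read by paw edema, with stated times of 1 h and 24 h, at a dose of 50 mg/kg by the intraperitoneal route; on this read-out higher numbers stand for more inhibition at the one dose given (going by the name of the read-out) and lower numbers for less inhibition:
compound 1 `CCOC(=O)c1c(-c2ccc(Cl)c(Cl)c2)cc(-c2ccccc2)nc1N1CCCCC1` gives 48.9%
compound 2 `CCOC(=O)c1c(-c2ccc(Cl)cc2)cc(-c2ccccc2)nc1N1CCN(C)CC1` gives 53.2%
compound 3 `CCOC(=O)c1c(-c2ccc(Cl)cc2)cc(-c2ccccc2)nc1Nc1ccc(C)cc1` gives 62.7%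

Compound 3 holds the highest of the three numbers; its gap to compound 2, a number 9.5 percentage points higher from compound 2 to compound 3 (within the scatter), is within the scatter, while its gap to compound 1 is beyond it. Compound 1 and compound 2 differ in two places, so their values are only read side by side.

Compound 4 `CCOC(=O)c1c(-c2ccc(Cl)c(Cl)c2)cc(-c2ccccc2)nc1Nc1ccc(C)cc1` is not yet measured. It differs from compound 3 by chloro in place of hydrogen on an aromatic carbon; read one bond further out, 4-chlorophenyl becomes 3,4-dichlorophenyl. Among the compounds with values here, no measured step in this assay changes only that position. Within the data shown here, the one measured step, a number 9.5 percentage points higher from compound 2 to compound 3 (within the scatter), concerns the amine side and sits within the scatter, so it does not bear directly on the chloro addition. Among the measured compounds shown here, with no step on this change, no shift beyond the scatter is expected; the estimate for compound 4 is 60%, range 48% to 72%, which is expected to mean a step of a number 2.7 percentage points lower from compound 3 to compound 4 (within the scatter).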

Compound 4, a percentage reported as inhibition, in the whole organism at one dose (the size of the read-out at that dose, not a potency): 40.8%
For compound 4 the middle estimate is 19.2 percentage points above the measured one; measured number below the stated range.
By their numbers in this assay, from the lowest: compounds 4, 1, 2 and 3 (each within the scatter of the next, the first and the last beyond it).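

In this assay, within the data shown here, this is the first measured change at this position: chloro in place of hydrogen, turning 4-chlorophenyl into 3,4-dichlorophenyl, gives a number 21.9 percentage points lower from compound 3 to compound 4 (beyond the scatter) with (4-methylphenyl)amino held fixed, so the position is not silent. With 3,4-dichlorophenyl held fixed, swapping the amine group gives a number 8.1 percentage points lower from compound 1 to compound 4 (within the scatter) and so does not separate (4-methylphenyl)amino from piperidin-1-yl. Nothing at hand gives a cause for the step on adding chloro.

Open, as far as these compounds go, is whether a fluoro or methoxy group at this position would give a step of like size, or whether the step is particular to chloro. Also open, from the compounds shown here alone, is whether adding chloro here carries the same step when piperidin-1-yl or 4-methylpiperazin-1-yl is the amine group.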